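Switching an ether chain for a pyrrolidine ring on an oxime cation

This account rests on a few compounds, and the source may have more. Where it says the series, first, only, none or still open, it means among the compounds named here.

Compound 1, `COCCOCn1cc[n+](C)c1/C=N/O`, gives -2.81 in a physicochemical assay for lipophilicity; a lower number here means a more polar compound, a higher number a more lipophilic compound.
Compound 2, `C[n+]1ccn(CCOCCF)c1/C=N/O`, gives -2.62 in this assay.
Compound 3, `C[n+]1ccn(COCCCCCl)c1/C=N/O`, gives -1.47 in this assay.

Among these three numbers compound 2 stands second highest: its nearest neighbour is compound 1, within the scatter of it, while compound 3 lies well beyond the scatter above it. All three share the same cation core and differ only in the chain on the ring nitrogen.

Compound 4, `C[n+]1ccn(CCN2CCCC2)c1/C=N/O`, is not yet measured. It changes compound 2 in one place: pyrrolidin-1-yl in place of 2-fluoroethoxy on a saturated chain carbon, two bonds along the chain from an aromatic nitrogen.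

Two measured steps speak to the chain. The step of a number 0.19 log units higher from compound 1 to compound 2 (within the scatter) shows that swapping one oxygen-containing chain for another barely moves the number, whereas a number 1.34 log units higher from compound 1 to compound 3 (beyond the scatter) shows that replacing a methoxy by a 2-chloroethyl moves it far. Among the compounds with values here, neither step brings in a ring or a nitrogen in the chain, so the new change has no close precedent. The heavy-atom count hardly changes, and a polar atom stays in the chain. A small step downward is expected, a number 0.38 log units lower from compound 2 to compound 4 (beyond the scatter), with a wide band. Compound 4 is therefore expected to give about -3, between -3.8 and -2.2.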

Compound 4, distribution coefficient: -2.73
Compound 4: the middle estimate sits 0.27 log units below what was measured; measured number inside the range.
By their numbers in this assay, from the lowest: compounds 1, 4 and 2 (each within the scatter of the next); then compound 3.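

In this assay, putting pyrrolidin-1-yl in place of 2-fluoroethoxy on a saturated chain carbon, two bonds along the chain from an aromatic nitrogen, gives a number 0.11 log units lower from compound 2 to compound 4 (within the scatter) and so stays within the usual spread of repeat measurements. The earlier steps shown here changed only open chains, whereas this one shows that a five-membered non-aromatic ring containing nitrogen can enter this position without a measurable shift in the read-out, even though the oxygen and fluorine of the leaving group are gone. The data shown offer no explanation for this result.

Going by these compounds, whether a morpholine ring or an open-chain diethylamino group would behave in the same way at this position remains open. So does the effect of a longer chain between the aromatic nitrogen and the pyrrolidine ring.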